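Swapping fluoro for 3-hydroxypropyl on compound 3

This account rests on a few compounds, and the source may have more. Where it says the series, first, only, none or still open, it means among the compounds named here.

In an ADME assay on microsomes from liver (Canis lupus familiaris) for metabolic stability, with a stated time of 10 min (on this read-out lower numbers stand for a less stable compound and higher numbers for a more stable compound), compound 1 `FC(F)(F)c1ccccc1-c1ccc2[nH]c(C3=NCC4(CCCCC4)O3)nc2c1` gives 40% and compound 2 `Fc1ccccc1-c1ccc2[nH]c(C3=NOC4(CCCCC4)C3)nc2c1` gives 47% as measured. Compound 3 `Fc1cc(-c2ccccc2C(F)(F)F)cc2nc(C3=NOC4(CCCCC4)C3)[nH]c12` stands highest of the three at 87% and lies beyond the scatter above both others. Among the compounds with values here, compound 4 `OCCCc1cc(-c2ccccc2C(F)(F)F)cc2nc(C3=NOC4(CCCCC4)C3)[nH]c12` carries 3-hydroxypropyl in place of fluoro on an aromatic carbon and has no measurement yet. Within the data shown here, no measured pair isolates this swap, so the expectation rests on thin ground. Among the measured compounds shown here, with compound 3 at 87% as the top of the numbers so far, a fall beyond the scatter is expected rather than a rise. In this assay the expected change is a number 32 percentage points lower from compound 3 to compound 4 (beyond the scatter) as a rough estimate. For compound 4 the estimated value is 55% with 30% to 80% as the expected range.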

Compound 4, percent of the compound remaining: 12%
Compound 4: the middle estimate sits 43 percentage points above what was measured; the whole stated range lies above it.
By their numbers in this assay, from the lowest: compound 4; then compounds 1 and 2 (each within the scatter of the next); then compound 3.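

Placing 3-hydroxypropyl in place of fluoro, on the aromatic carbon ortho to a fused ring, gives a number 75 percentage points lower from compound 3 to compound 4 (beyond the scatter) in this assay. Within the data shown here, this is the only reading that isolates a change at this position, and it shows that the high number of compound 3 does not survive this swap. Nothing measured here bears on the reason for the fall.

Open, from the compounds shown here alone, is whether the fall follows the chain itself or its terminal hydroxyl. A plain propyl, a hydroxymethyl, an amine or a carboxylic acid on the same carbon would separate these readings.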